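Sulfamate Series: A Pyridylmethyl Amine Replaces Dipropylamine

The compounds below may be only part of what the source reports. "The series", "measured", "known", "first", "only" and "open" are said of these compounds alone.

This account follows two sulfamate-bearing compounds and a third one yet to be tested. Compound 1 `CCCN(CCC)c1cccc(C(=O)N2CCc3ccc(OS(N)(=O)=O)cc3C2)c1` was examined in an assay on HEK293 cells for inhibition of Steryl-sulfatase (Homo sapiens), tested at 0.1 uM (on this read-out lower numbers stand for a weaker effect and higher numbers for a stronger effect at the one concentration tested), where compound 1 gives 8.3%. Its companion, compound 2 `NS(=O)(=O)Oc1ccc2c(c1)CN(C(=O)c1ccc(N3CCN(c4ncccn4)CC3)cc1)CC2`, gives in this assay a read-out of 14.7%; the two numbers lie within the scatter of each other, so the data show no separation between compound 1 and compound 2 on this read-out.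

The untested compound, compound 3 `CCN(Cc1ccncc1)c1cccc(C(=O)N2CCc3ccc(OS(N)(=O)=O)cc3C2)c1`, differs from compound 1 in one place: ethyl((pyridin-4-yl)methyl)amino in place of dipropylamino on an aromatic carbon. For the measured compounds named here, no measured pair in the set shares this change, so there is no step to lean on. With both known numbers sitting close together, the step from compound 1 to compound 3 in this assay is expected to be small, and the estimate is a number 2.7 percentage points higher from compound 1 to compound 3 (within the scatter), not beyond the scatter in either direction. Compound 3 is therefore expected to give about 11%, in the range of 0% to 26%.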

Compound 3, a percentage reported as inhibition, at one concentration (the size of the read-out at that concentration, not a potency): 33.3%
The estimate for compound 3 lay 22.3 percentage points below the measured number; the measured number lies above the stated range.
By their numbers in this assay, from the lowest: compounds 1 and 2 (each within the scatter of the next); then compound 3.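

In this assay, ethyl((pyridin-4-yl)methyl)amino in place of dipropylamino on an aromatic carbon, meta to a large group, gives a number 25 percentage points higher from compound 1 to compound 3 (beyond the scatter). For the compounds shown here, this is the first step in the set that can be tied to one place, as compound 1 and compound 2 differ in more than one place, and it shows that the read-out at the one concentration tested responds to the group at this position. Nothing at hand explains the step.

The compounds shown leave open which part of the change carries the step: the pyridine ring, its nitrogen, or the loss of the propyl chains. A benzyl group on the same amine would separate the ring nitrogen from the ring itself, and a propyl chain in place of the ethyl would test the remaining alkyl group.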